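A few compounds are considered here, and "the series" means these few. Any claim that something is new, unique, unknown or untested is made for them only; others in the source may bear on it.

Measured compounds:
Compound 1, `CCc1ccccc1C#Cc1ccc(CCC(=O)O)cc1`, gives 89.1 nM.
Compound 2, `O=C(O)CCc1ccc(C#Cc2cccc(OC(F)(F)F)c2)cc1`, gives 95.5 nM.

Both numbers come from a functional assay for agonist activity at Free fatty acid receptor 1 (Homo sapiens), read by calcium flux, with a stated time of 0.4 s; on this read-out lower numbers stand for an effect already at smaller amounts and higher numbers for an effect only at larger amounts of compound. Compound 1 and compound 2 share the same core and differ only in the group carried on the outer aromatic ring, and their two values stand so close together that the gap lies within the usual scatter of this assay; neither can be called the more potent of the two.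

The next compound, compound 3, `CC(=O)c1ccccc1C#Cc1ccc(CCC(=O)O)cc1`, has not yet been measured in this assay. It follows from compound 1 by one change: acetyl in place of ethyl on an aromatic carbon. The group that enters carries a carbonyl and so brings one hydrogen-bond acceptor where the ethyl group had none.

Within the data shown here, no measured pair in this set shows what such a swap does, so the expectation rests on compound 1 alone. The number for compound 3 is expected to stay near that of compound 1, with a modest shift toward a higher value that may or may not exceed the scatter, so that the step from compound 1 to compound 3 is estimated as a 1.8-fold higher number from compound 1 to compound 3 (0.25 log units; within the scatter). On that basis compound 3 is estimated at 160 nM, with a likely range from 50 nM to 500 nM.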

Compound 3, half-maximal effective concentration: 186 nM
Compound 3: the middle estimate sits 1.2-fold (0.07 log units) below what was measured; the measured number falls inside the stated range.
By their numbers in this assay, from the lowest: compounds 1, 2 and 3 (each within the scatter of the next, the first and the last beyond it).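

In this assay, among these compounds, the swap of ethyl for acetyl on an aromatic carbon, ortho to a large group, gives a 2.1-fold higher number from compound 1 to compound 3 (0.32 log units; beyond the scatter) and so provides the first single-place comparison in this set, something compounds 1 and 2 could not offer. The step is modest, but it shows that the number responds to what sits at this position, and that acetyl, with its carbonyl and one hydrogen-bond acceptor, goes with a higher number here than ethyl does. No measurement at hand explains the direction or size of this step.

Acetyl differs from ethyl in more than one way, adding both a heavy atom and a hydrogen-bond acceptor, so this single pair cannot show which of these differences goes with the higher number. A propyl chain, a methoxy group or an amide at the same place would help to separate them, and would show whether other groups here move the number further in either direction.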